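A few compounds are considered here, and "the series" means these few. Any claim that something is new, unique, unknown or untested is made for them only; others in the source may bear on it.

Measured so far in a functional assay on CHO cells for agonist activity at Free fatty acid receptor 1 (Homo sapiens), read by FLIPR, tested at 100 nM; a higher number here means a stronger effect of the compound at the concentration tested, a lower number a weaker effect:
compound 1 `O=C(O)COc1ccc(NC(=O)Nc2ccccc2)cc1F` gives 8.47%;
compound 2 `CCOc1ccccc1OC(C)C(=O)Nc1ccc(OCC(=O)O)c(F)c1` gives 8.79%;
compound 3 `CC(C)c1ccc(OCC(=O)Nc2ccc(OCC(=O)O)c(F)c2)cc1` gives 11.8%.

All three readings are small, and the gaps among them stay within the usual scatter of repeated measurements, so none of the three can be called more active than another. Compound 2 sits with a number very close to that of compound 1 and not far from that of compound 3. Compound 4 `Cc1ccc(OC(C)C(=O)Nc2ccc(OCC(=O)O)c(F)c2)cc1C` has not yet been measured. It differs from compound 2 in one place: 3,4-dimethylphenyl in place of 2-ethoxyphenyl on an oxygen on a saturated carbon. Among the measured compounds shown here, no measured pair shows what such a swap does. With every measured reading low, the expected step from compound 2 to compound 4 in this assay is none beyond the scatter, namely a number 1.2 percentage points higher from compound 2 to compound 4 (within the scatter). Compound 4 is therefore estimated at 10%, most likely between 3% and 22%.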

Compound 4, a percentage reported as activity, at one concentration (the size of the read-out at that concentration, not a potency): 36.8%
The estimate for compound 4 lay 26.8 percentage points below the measured number, outside the stated range (above it).
By their numbers in this assay, from the lowest: compounds 1, 2 and 3 (each within the scatter of the next); then compound 4.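

Among the compounds shown here, at this position, on an oxygen on a saturated carbon, the choice of aromatic group can move the read-out: with 3,4-dimethylphenyl in place of 2-ethoxyphenyl, this assay shows a number 28 percentage points higher from compound 2 to compound 4 (beyond the scatter) and so gives the first step here that clears the scatter. The swap removes the ethoxy group and adds two methyl groups at once, so the step cannot be assigned to either change alone. Nothing measured here explains the rise. Going by these compounds, whether one methyl group would be enough remains open. So does the outcome with an unsubstituted phenyl, or with chlorine or trifluoromethyl on the ring.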